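A few compounds are considered here, and "the series" means these few. Any claim that something is new, unique, unknown or untested is made for them only; others in the source may bear on it.

Measured compounds:
- compound 1, `CNc1nc(NC2(C#N)CCCCC2)nc(-n2cccn2)n1`: > 5000 nM, a limit of the assay
- compound 2, `CNc1nc(NC)nc(NC2(C#N)CCCCC2)n1`: > 1000 nM, a limit of the assay
- compound 3, `CNc1nc(NC2(C#N)CCCCC2)nc(N2CCCC2)n1`: > 5000 nM, a limit of the assay

In an in vitro assay on Sf21 cells for inhibition of high affinity 3',5'-cyclic-AMP phosphodiesterase 7A (Homo sapiens) (on this read-out lower numbers stand for stronger inhibition and higher numbers for weaker inhibition), compound 1 gives > 5000 nM, which is a limit and not a number. Compound 1 therefore stands nowhere definite on the numbers shown; only a limit is known for it, and the two other values shown are limits as well, as the limit of > 1000 nM in this assay, at which 1 of the 3 values shown sits, and the limit of > 5000 nM in this assay, at which 2 of the 3 values shown sit, record. Between them, a step that the two limits leave unreadable from compound 1 to compound 2, a step that the two limits leave unreadable from compound 1 to compound 3 and a step that the two limits leave unreadable from compound 2 to compound 3 cannot be read in size, because both ends of each step are limits.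

Compound 4, `CNc1nc(NC2(C#N)CCCCC2)nc(OC)n1`, differs from compound 1 in one place: methoxy in place of 1H-pyrazol-1-yl on an aromatic carbon. For the measured compounds named here, no measured step bears readably on this change, since every neighbour of compound 1 sits at a limit. The shared core with the nitrile-bearing ring and the methylamino group has given no readable number in any of the three compounds shown, so for compound 4 a weak result is expected, most likely again a limit, with a step that the limit leaves unreadable from compound 1 to compound 4 as the expected step. The estimate for compound 4 in this assay is 8000 nM, expected to fall between 2000 nM and 30000 nM.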

Compound 4, half-maximal inhibitory concentration: 521 nM
Beside the measured number, compound 4's estimate is 15-fold (1.19 log units) above it, outside the stated range (below it).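

In this assay, the group on this carbon, opposite the ring nitrogen, proves able to move the result: methoxy gives the first readable number among the compounds shown. Replacing 1H-pyrazol-1-yl gives an at least 9.5-fold lower number from compound 1 to compound 4 (0.98 log units; beyond the scatter) and replacing pyrrolidin-1-yl gives an at least 9.5-fold lower number from compound 3 to compound 4 (0.98 log units; beyond the scatter) so the larger ring groups and methoxy are clearly separated. Replacing methylamino gives an at least 1.9-fold lower number from compound 2 to compound 4 (0.28 log units; that floor lies within the scatter) so that change cannot yet be told from the scatter, while the steps among compounds 1, 2 and 3 remain unreadable. Nothing measured here explains why methoxy gives a readable number where the other three groups give only limits.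

Still open, on these data alone, is how the number responds to other groups on this carbon, such as ethoxy or a longer chain ending in an amine.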